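A Furan for a Thiophene on the Cyclopropane Ring

The source may report more compounds than this note shows. Statements on the series, on what has been measured and on what is new or still open speak of the compounds shown alone.

Going by the values given here, compound 2 `CC[C@H](C)[C@H](N)CN(C(=O)[C@@H]1C[C@H]1c1cccs1)c1ccc(-c2ccccc2)cc1` is the stronger of the two compounds measured so far. In a functional assay for agonist activity at G protein-coupled receptor 88 (Homo sapiens), read by HTRF and cAMP accumulation (on this read-out higher numbers stand for an effect only at larger amounts of compound and lower numbers for an effect already at smaller amounts), compound 2 gives 360 nM, whereas compound 1 `CC[C@H](C)[C@H](N)CN(C(=O)[C@@H]1C[C@H]1c1ccc(Cl)cc1)c1ccc(-c2ccccc2)cc1` gives 4300 nM in this assay. Among the compounds with values here, the one measured step, a 12-fold lower number from compound 1 to compound 2 (1.08 log units; beyond the scatter), sits at the same saturated ring carbon that is changed here. Within the data shown here, it is the only precedent that bears on the next compound, and it shows that this position can move the number a great deal.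

Compound 3 `CC[C@H](C)[C@H](N)CN(C(=O)[C@@H]1C[C@H]1c1ccoc1)c1ccc(-c2ccccc2)cc1` carries the change (furan-3-yl in place of thiophen-2-yl on a saturated ring carbon). Among the measured compounds shown here, no measured step compares one five-membered heteroaromatic ring with another at this position, so the direction of the step cannot be read from the data; the size of the earlier step only warns that the change may not be small.

Compound 3 is therefore expected to sit near compound 2, with a wide range, at an estimated 600 nM, between 150 nM and 3000 nM. The step this estimate implies, a 1.7-fold higher number from compound 2 to compound 3 (0.22 log units; within the scatter), is expected to stay within the scatter.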

Compound 3, half-maximal effective concentration: 580 nM
Compound 3: middle estimate off by 1.0-fold (0.01 log units), on the high side; the measured number falls inside the stated range.
By their numbers in this assay, from the lowest: compounds 2 and 3 (each within the scatter of the next); then compound 1.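

In this assay, one five-membered aromatic ring with one hetero atom replaces another on this saturated ring carbon with a 1.6-fold higher number from compound 2 to compound 3 (0.21 log units; within the scatter), so compound 2 and compound 3 cannot be told apart, even though the sulfur of thiophen-2-yl gives way to the oxygen of furan-3-yl and the name of the ring's attachment point changes as well. The advantage over 4-chlorophenyl is thus not confined to thiophen-2-yl: furan-3-yl also shows a 7.4-fold lower number from compound 1 to compound 3 (0.87 log units; beyond the scatter), which sits beside the earlier 12-fold lower number from compound 1 to compound 2 (1.08 log units; beyond the scatter), and no listed compound goes against this within the three compared. Nothing measured alongside these numbers accounts for them.

Since the hetero atom and the point of attachment differ together between compound 2 and compound 3, the contribution of each remains unresolved, and furan-2-yl or thiophen-3-yl at this carbon would be needed to separate them. As far as these compounds go, it also remains open whether the step from compound 1 reflects the five-membered ring or the loss of the chlorine, a question that an unsubstituted phenyl at the same carbon would address.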